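Swapping an amine-bearing side chain for a fluoropyridyl ring

The source may hold more compounds than are shown below. What is called first, only, known or untested is meant among the compounds shown, and "the series" means these compounds.

Compound 1 `COc1cc(OC)c2c(=O)cc(-c3ccc(OCCCN(C)C)cc3)oc2c1`: 36%
Compound 2 `COc1cc(OC)c2c(=O)cc(-c3ccc(OCCN4CCCC4=O)cc3)oc2c1`: 7%
Compound 3 `COc1cc(OC)c2c(=O)cc(-c3ccc(OCC(O)CN4CCCC4)cc3)oc2c1`: 21%

Of the compounds shown here, three sharing one core have been tested in a functional assay (Homo sapiens) for antiproliferative activity, read by resazurin assay, with a stated time of 48 h, tested at 5 uM; on this read-out higher numbers stand for a stronger effect at the one concentration tested and lower numbers for a weaker effect. Compound 1 stands highest of the three; its nearest neighbour is compound 3, which lies a number 15 percentage points lower from compound 1 to compound 3 (beyond the scatter), and the furthest is compound 2, which lies a number 29 percentage points lower from compound 1 to compound 2 (beyond the scatter). Between the two lower compounds the difference is a number 14 percentage points higher from compound 2 to compound 3 (beyond the scatter).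

Compound 4 `COc1cc(OC)c2c(=O)cc(-c3ccc(-c4ccc(F)nc4)cc3)oc2c1` differs from compound 1 in one place: 6-fluoropyridin-3-yl in place of 3-(dimethylamino)propoxy on an aromatic carbon. All three measured steps concern exchanges within the 3-(dimethylamino)propoxy side chain, and each departure from compound 1 gave a modestly lower number. Among the compounds with values here, none of them replaces that chain with an aromatic ring, so no measured step bears directly on the change to compound 4. Given that every change to this position so far lowered the number, a modest drop is expected for compound 4, with the wide uncertainty that follows from an untested type of change; the estimated step is a number 12 percentage points lower from compound 1 to compound 4 (beyond the scatter). For compound 4 the expected value in this assay is 24%, within a range from 5% to 50%.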

Compound 4, a percentage reported as inhibition, at one concentration (the size of the read-out at that concentration, not a potency): "not active" (no number reported)
For compound 4 the study gives words and no number, so the estimate cannot be set against anything.
By their numbers in this assay, from the lowest: compound 2; then compound 3; then compound 1.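

In this assay, within the data shown here, compound 4 is reported only in words, as not active, so no step from compound 1 to compound 4 can be read. Nothing measured here accounts for this result. The compounds shown leave open whether any aromatic ring in place of 3-(dimethylamino)propoxy keeps a measurable effect.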